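Methylating the Amine Nitrogen of Compound 2

This account rests on a few compounds, and the source may have more. Where it says the series, first, only, none or still open, it means among the compounds named here.

Compound 1 `c1ccc(-c2cc(NCC3CC3)ncn2)nc1`: 22000 nM
Compound 2 `CNc1nc(NCC2CC2)cc(-c2ccccn2)n1`: 164 nM

In a functional assay on HEK293 cells for agonist activity at G-protein coupled receptor 39 (Homo sapiens), read by inositol phosphate accumulation (on this read-out higher numbers stand for an effect only at larger amounts of compound and lower numbers for an effect already at smaller amounts), compound 2 stands lowest of the two numbers; its nearest neighbour is compound 1, reached by the step of a 130-fold lower number from compound 1 to compound 2 (2.13 log units; beyond the scatter). Compound 3 `CN(C)c1nc(NCC2CC2)cc(-c2ccccn2)n1` differs from compound 2 by methyl in place of hydrogen on a nitrogen on an aromatic ring. Among the measured compounds shown here, no measured step covers this exact change; the step from compound 1 to compound 2 touches the same group but adds the whole methylamino rather than a second methyl, so it only loosely bears on it. A modest shift is therefore expected, in either direction, possibly none beyond the scatter. The step from compound 2 to compound 3 is estimated as a 2.4-fold higher number from compound 2 to compound 3 (0.39 log units; beyond the scatter). Compound 3 is expected to give 400 nM, within 80 nM to 2500 nM.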

Compound 3, half-maximal effective concentration: > 25000 nM
Compound 3 gave a limit, no number (the forecaster's own chance of this, stated with the estimate: 3%); middle value at least 62-fold (1.79 log units) away from the limit.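

A single methyl on this nitrogen is enough to undo the gain that methylamino brought, since the change gives an at least 150-fold higher number from compound 2 to compound 3 (2.18 log units; beyond the scatter) and so counts as a large step. Measured against compound 1, dimethylamino shows no gain at all: the comparison gives only an at least 1.1-fold higher number from compound 1 to compound 3 (0.05 log units; that floor lies within the scatter) as its floor. Compound 3 gives a limit of the assay, not a number: the limit of > 25000 nM in this assay, at which 1 of the 3 values shown sits.

Still open, as far as these compounds go, is how an unsubstituted amino group or ethylamino would fare on this aromatic carbon. Also open, from the compounds shown here alone, is whether any group in place of that nitrogen's hydrogen brings the same loss, or only methyl.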